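Trimming the Side Chain of Compound 2

This account rests on a few compounds, and the source may have more. Where it says the series, first, only, none or still open, it means among the compounds named here.

Three compounds have so far been examined in a functional assay on A549 cells (Homo sapiens) for cytotoxicity, read by MTT assay, with a stated time of 72 h; on this read-out higher numbers stand for weaker inhibition and lower numbers for stronger inhibition. Compound 1 `C=C(C)CCOc1ccc(C(C)=O)c(O)c1` reaches only the limit of > 100000 nM. Compound 3 `C=C(C)CCOc1c(OC)cc(/C=C/CO)cc1OC` likewise reaches only the limit of > 100000 nM. Among the measured compounds shown here, compound 2 `COc1cc(/C=C/C=O)cc(OC)c1OC/C=C(\C)CCC=C(C)C` is the sole member to give a number, 71000 nM, and thus stands alone among the values shown. Compound 1 and compound 3 both sit at a limit (the limit of > 100000 nM in this assay, at which 2 of the 3 values shown sit).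

Compound 4 `COc1cc(/C=C/C=O)cc(OC)c1OCC=C(C)C` has yet to be measured. It differs from compound 2 in one place: hydrogen in place of 3-methylbut-2-en-1-yl on a saturated chain carbon bound to a double-bonded chain carbon. For the measured compounds named here, no step between two measured compounds is available to anchor the size of such a change, so the expectation in this assay rests on compound 2 alone. With every other value shown sitting at a limit, the change is expected to stay within the scatter or to drift toward weaker inhibition, with a fair chance that only a limit is reported. Compound 4 is therefore estimated at 90000 nM, within a range from 35000 nM to 250000 nM. The step so expected is a 1.3-fold higher number from compound 2 to compound 4 (0.10 log units; within the scatter).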

Compound 4, half-maximal inhibitory concentration: 68000 nM
Compound 4: middle estimate off by 1.3-fold (0.12 log units), on the high side; the measured number falls inside the stated range.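

In this assay, hydrogen in place of 3-methylbut-2-en-1-yl on a saturated chain carbon bound to a double-bonded chain carbon gives a 1.0-fold lower number from compound 2 to compound 4 (0.02 log units; within the scatter). Among the compounds shown here, this is the first step between two measured compounds, and it shows that, for this pair, the 3-methylbut-2-en-1-yl group can leave the chain without a change that can be told from the scatter. Compound 4 also gives a number rather than a limit, while compound 1 and compound 3 each remain at a limit: the limit of > 100000 nM in this assay, at which 2 of the 4 values shown sit.

Going by these compounds, whether a carboxylic acid or an amine at the end of the chain, or a benzyl group in its place, would move the number remains open. The compounds shown also give no step that tells how far any change to the shared core would carry.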